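This account rests on a few compounds, and the source may have more. Where it says the series, first, only, none or still open, it means among the compounds named here.

Measured compounds:
- compound 1, `C=C[C@@H]1O[C@H](COCc2ccccc2)[C@@H](OCc2ccccc2)[C@H](OCc2ccccc2)[C@H]1O`, in a functional assay on HL-60 cells (Homo sapiens) for antiproliferative activity, read by MTT assay (a lower number here means a stronger inhibitor, a higher number a weaker inhibitor), gives 11800 nM
- compound 2, `C=C[C@H]1O[C@H](COCc2ccccc2)[C@@H](OCc2ccccc2)[C@H](OCc2ccccc2)[C@H]1O`, in this assay gives "not active" (no number reported)

Within the data shown here, compound 1 is the only compound of the pair for which a number is reported in this assay; compound 2 was reported as not active without a number. Among the measured compounds shown here, the two differ only in configuration at the ring carbon that carries the vinyl group, so the one comparison on hand turns on (the fact that compounds 1 and 2 differ only in the configuration as drawn), and it does not supply a measured step whose size could be carried over.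

Compound 3, `CCCC[C@@H]1O[C@H](COCc2ccccc2)[C@@H](OCc2ccccc2)[C@H](OCc2ccccc2)[C@H]1O`, keeps the core of compound 1 and differs from it by butyl in place of vinyl on a saturated ring carbon. For the measured compounds named here, with no measured step of this kind to lean on, the size of the change in this assay is open; a step beyond the usual scatter in either direction is possible, but a small one is the more likely outcome.

Compound 3 is expected to give an estimate of 8000 nM in this assay, within a range from 3000 nM to 25000 nM, which means an expected step of a 1.5-fold lower number from compound 1 to compound 3 (0.17 log units; within the scatter).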

Compound 3, half-maximal inhibitory concentration: "not active" (no number reported)
Compound 3 has no reported number here, so the estimate cannot be set against anything.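

Among these compounds, compound 3 was reported as not active in this assay without a number, so no step from compound 1 to compound 3 can be read, and the same holds for compound 2. Nothing shown here accounts for this result. The compounds shown leave open how large a change butyl in place of vinyl brings.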